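The compounds below may be only part of what the source reports. "The series", "measured", "known", "first", "only" and "open" are said of these compounds alone.

Compound 1 `O=C(CCc1ccc(Cl)cc1)C(=O)N1CCCCC1` — > 10000 nM
Compound 2 `O=C(CCc1ccc(Cl)cc1)C(=O)N1CC[C@@H](c2ccccc2)C1` — > 10000 nM

In an assay on HEK-293T cells for inhibition of phospholipase A and acyltransferase 5 (Homo sapiens), with stated times of 30 min and 20 min (a lower number here means a stronger inhibitor, a higher number a weaker inhibitor), compound 1 gives > 10000 nM, which is a limit of the assay rather than a number. Compound 2 gives > 10000 nM in this assay, again a limit and not a number. Going by the values given here, compound 2 therefore stands at the limit, and the evidence is simply (the limit of > 10000 nM in this assay, at which 2 of the 2 values shown sit); with both values at the limit, no step between measured compounds can be counted.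

Compound 3 `O=C(CCc1ccc(Cl)cc1)C(=O)N1CCCC1` is still to be measured in this assay. Going from compound 2 to compound 3, the change is hydrogen in place of phenyl on a saturated ring carbon. Among the compounds with values here, no measured step speaks to this kind of change, so its size cannot be read from the data. The step from compound 2 to compound 3 is expected to be a step that the limit leaves unreadable from compound 2 to compound 3, that is, no movement beyond the scatter. Compound 3 is expected to give about 20000 nM, within 5000 nM to 100000 nM, most likely as another limit. This expectation rests on (the limit of > 10000 nM in this assay, at which 2 of the 2 values shown sit).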

Compound 3, half-maximal inhibitory concentration: > 10000 nM
Compound 3: only a limit was reported (the forecaster's own chance of this, stated with the estimate: 85%); the middle value is on the limit's open side.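

In this assay compound 3 gives > 10000 nM, again a limit and not a number. Going by these compounds alone, no step from compound 1 or compound 2 to compound 3 can therefore be read. The compounds shown leave open which change to the shared core, if any, would give a measurable value: the limit of > 10000 nM in this assay, at which 3 of the 3 values shown sit.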